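This account rests on a few compounds, and the source may have more. Where it says the series, first, only, none or still open, it means among the compounds named here.

In a functional assay on SMMC-7721 cells (Homo sapiens) for antiproliferative activity, read by MTT assay, with a stated time of 48 h (a higher number here means a weaker inhibitor, a lower number a stronger inhibitor), compound 1 `CC(C)=CCC[C@]1(C)/C=C/[C@@H](OC(=O)C=C(C)C)[C@](C)(O)/C=C/C(=O)/C(CN(C)C)=C\C1` gives 820 nM, and compound 2 `CC(C)=CCC[C@]1(C)/C=C/[C@@H](OC(=O)C=C(C)C)[C@](C)(O)/C=C/C(=O)/C(CN2CCCC2)=C\C1` gives 140 nM, the lower of the two numbers. Compound 3 `CC(C)=CCC[C@]1(C)/C=C/[C@@H](OC(=O)C=C(C)C)[C@](C)(O)/C=C/C(=O)/C(COC(=O)c2ccc([N+](=O)[O-])cc2)=C\C1` has a larger change: ((4-nitrophenyl)carbonyl)oxy in place of pyrrolidin-1-yl on a saturated chain carbon bound to a double-bonded ring carbon, with ((4-nitrophenyl)carbonyl)oxy in place of pyrrolidin-1-yl on a saturated chain carbon bound to a double-bonded ring carbon. Within the data shown here, only one measured step bears on this place, the modest 5.9-fold lower number from compound 1 to compound 2 (0.77 log units; beyond the scatter), and it swaps one nitrogen group for another, so it is a loose guide. A step of similar size, a 5.7-fold higher number from compound 2 to compound 3 (0.76 log units; beyond the scatter), is expected in this assay, toward a higher number. For compound 3 the estimate is 800 nM, with an expected range from 200 nM to 4000 nM.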

Compound 3, half-maximal inhibitory concentration: 2560 nM
Estimate against measurement, compound 3: 3.2-fold (0.51 log units) below; measured number inside the range.
By their numbers in this assay, from the lowest: compound 2; then compound 1; then compound 3.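

In this assay, the ((4-nitrophenyl)carbonyl)oxy group gives a higher number than either nitrogen group at this position: an 18-fold higher number from compound 2 to compound 3 (1.26 log units; beyond the scatter), and a 3.1-fold higher number from compound 1 to compound 3 (0.49 log units; beyond the scatter). The choice of group here can therefore move the number further than the swap between the two nitrogen groups did, although compound 3 still gives a measured value. No measurement shown explains these steps. From the compounds shown here alone, it remains open whether the rise belongs to the ester link or to the 4-nitrophenyl ring, and how a plain benzoyloxy group or a morpholine ring would compare at this place.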